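Working notes: bromo in place of chloro

The compounds below may be only part of what the source reports. "The series", "measured", "known", "first", "only" and "open" are said of these compounds alone.

Measured in a functional assay on MGC-803 cells (Homo sapiens) for inhibition, read by MTT assay, with a stated time of 48 h; a higher number here means a weaker inhibitor, a lower number a stronger inhibitor:
compound 1 `COc1ccc(CNc2cc(OC)c(OC)c(OC)c2)cc1[N+](=O)[O-]` gives 19400 nM
compound 2 `COc1ccc(CNc2cc(OC)c(OC)c(OC)c2)cc1Cl` gives 46200 nM

Of the two measured compounds, compound 2 has the higher number and is the weaker inhibitor, with compound 1 as its nearest neighbour. Compound 3 `COc1ccc(CNc2cc(OC)c(OC)c(OC)c2)cc1Br` differs from compound 2 in one substituent, on an aromatic carbon ortho to a methoxy group: bromo in place of chloro on an aromatic carbon. For the measured compounds named here, only one measured step bears on this change: a 2.4-fold higher number from compound 1 to compound 2 (0.38 log units; beyond the scatter). That step is modest, and it exchanges nitro for chloro, so it is a loose guide. No exchange of one halogen for another has been measured in this series. In this assay, no step beyond the scatter is expected, and neither direction is favoured. The estimated change is a 1.2-fold lower number from compound 2 to compound 3 (0.06 log units; within the scatter). The estimated value for compound 3 is 40000 nM, with an expected range from 17000 nM to 90000 nM.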

Compound 3, half-maximal inhibitory concentration: 29400 nM
Compound 3: the middle estimate sits 1.4-fold (0.13 log units) above what was measured; the measured number falls inside the stated range.
By their numbers in this assay, from the lowest: compounds 1, 3 and 2 (each within the scatter of the next, the first and the last beyond it).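

In this assay, this position, ortho to a methoxy group, now has a direct exchange of one halogen for another, and that exchange gives a 1.6-fold lower number from compound 2 to compound 3 (0.20 log units; within the scatter) and so does not separate bromo from chloro. Bromo in place of nitro gives a 1.5-fold higher number from compound 1 to compound 3 (0.18 log units; within the scatter) while chloro in place of nitro gave a 2.4-fold higher number from compound 1 to compound 2 (0.38 log units; beyond the scatter) and so only chloro is separated from nitro, although the two halogens cannot themselves be told apart. Nothing available on these compounds accounts for these numbers.

As far as these compounds go, it remains open whether fluoro, iodo, an amine or a carboxylic acid at this position would stay in the same range of numbers. Also open, from the compounds shown here alone, is whether the halogen exchange would read the same with the methoxy group replaced by a hydroxy group.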